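A few compounds are considered here, and "the series" means these few. Any claim that something is new, unique, unknown or untested is made for them only; others in the source may bear on it.

Compound 1 (`COc1cc(NC(C)CCCNC(=O)NN)c2ncccc2c1`) – > 250000 nM (a limit)
Compound 2 (`COc1cc(NC(C)CCCNC(=O)NNC(=O)NC(CO)(CO)CO)c2ncccc2c1`) – > 250000 nM (a limit)

In a functional assay on CCRF-CEM cells (Homo sapiens) for inhibition, read by MTT assay, with a stated time of 4 days (a lower number here means a stronger inhibitor, a higher number a weaker inhibitor), compound 2 stands at > 250000 nM, which is a limit and not a number. The other measured compound sits at the same limit (the limit of > 250000 nM in this assay, at which 2 of the 2 values shown sit). The next compound, compound 3 (`COc1cc(NC(C)CCCNC(=O)NNC(=O)N(CCO)CCO)c2ncccc2c1`), carries bis(2-hydroxyethyl)amino in place of (2-hydroxy-1,1-bis(hydroxymethyl)ethyl)amino on a carbonyl carbon.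

For the measured compounds named here, only one measured step bears on this change: a step that the two limits leave unreadable from compound 1 to compound 2. That step placed (2-hydroxy-1,1-bis(hydroxymethyl)ethyl)carbamoyl on an amine nitrogen in place of hydrogen, and its size cannot be read. It therefore offers no measured size to carry over, and it gives no direction for the new change. The expectation stays anchored on compound 2, with its limit of > 250000 nM.

No step beyond the usual scatter is expected in this assay, so the expected outcome is a number no higher from compound 2 to compound 3 (the limit leaves the size open). For compound 3 the estimate is 250000 nM, with an expected range of 120000 nM to 400000 nM, and most likely only a limit will be reported.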

Compound 3, half-maximal inhibitory concentration: > 250000 nM
Compound 3 gave a limit, no number (the forecaster's own chance of this, stated with the estimate: 80%); the middle value lies on the limit itself.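

In this assay compound 3 gives > 250000 nM, which is a limit and not a number. The steps to compound 3 from compound 1 and compound 2 therefore cannot be read: the limit of > 250000 nM in this assay, at which 3 of the 3 values shown sit.

The compounds shown leave open how strongly each one inhibits, and whether the group on the carbonyl carbon affects that strength at all.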